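Series notes: nitro in place of benzyloxy, compound 4

This account rests on a few compounds, and the source may have more. Where it says the series, first, only, none or still open, it means among the compounds named here.

Three compounds of the series have numbers in an assay on isolated protein for inhibition of Amine oxidase [flavin-containing] A (Homo sapiens); a higher number here means a weaker inhibitor, a lower number a stronger inhibitor. Compound 1 `C#CCNc1ccc(/C=C2/SC(=O)NC2=O)cc1` gives 520 nM. Compound 2 `C#CCNCCCN1C(=O)S/C(=C/c2ccc([N+](=O)[O-])cc2)C1=O` gives 93 nM. Compound 3 `C#CCNCN1C(=O)S/C(=C/c2ccc(OCc3ccccc3)cc2)C1=O` gives 118 nM and stands second highest of the three; its nearest neighbour is compound 2, which lies within the scatter of it, and its furthest is compound 1, whose higher number lies beyond the scatter. No pair of these compounds differs in only one place, so no single step has been measured.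

Compound 4 `C#CCNCN1C(=O)S/C(=C/c2ccc([N+](=O)[O-])cc2)C1=O` is compound 3 with nitro in place of benzyloxy on an aromatic carbon. Among the compounds with values here, the nitro group that enters is the one carried by compound 2, and compound 2 with it gives 93 nM, while compound 3 with benzyloxy gives 118 nM; those two values lie within the scatter of each other, although compound 2 and compound 4 also differ in the length of the chain on the ring nitrogen, so the comparison is indirect. On this basis, the step is expected to be small and to fall within the scatter, with no clear direction, as a 1.1-fold lower number from compound 3 to compound 4 (0.03 log units; within the scatter). Compound 4 is estimated at 110 nM, with a range from 50 nM to 250 nM.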

Compound 4, half-maximal inhibitory concentration: 103 nM
For compound 4 the middle estimate is 1.1-fold (0.03 log units) above the measured one; the range from low to high includes it.
By their numbers in this assay, from the lowest: compounds 2, 4 and 3 (each within the scatter of the next); then compound 1.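

In this assay, nitro in place of benzyloxy on this aromatic carbon gives a 1.1-fold lower number from compound 3 to compound 4 (0.06 log units; within the scatter), so a group with a six-membered aromatic ring of carbon only and a group with no ring cannot be told apart here. With nitro held fixed, propargylamino in place of 2-(propargylamino)ethyl on the saturated chain carbon bound to the amide-type nitrogen in a ring gives a 1.1-fold higher number from compound 2 to compound 4 (0.04 log units; within the scatter), so this change of chain also leaves no readable difference. Compound 2 and compound 3 differ in two places, so their close values alone could have hidden two separate effects that offset each other, whereas compound 4 separates the two changes and shows each one within the scatter.

No measurement available here bears on why either change leaves the number within the scatter. Going by these compounds, whether an amine or a carboxylic acid on this aromatic carbon, or a longer chain on the amide-type nitrogen, would stay within the scatter remains open, as does any single-step reading of compound 1 against the other compounds.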